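Working notes: aryl exchange on compound 1

The source may hold more compounds than are shown below. What is called first, only, known or untested is meant among the compounds shown, and "the series" means these compounds.

Values in an ADME assay on HEK293 cells (Homo sapiens) for cytotoxicity, read by MTT assay, with a stated time of 72 h; on this read-out higher numbers stand for weaker inhibition and lower numbers for stronger inhibition:
- compound 1 `COc1ccc(OC)c(C2=C(c3cc(OC)c(OC)c(OC)c3)C(=O)CC2O[SiH2]C(C)(C)C)c1`: 9.5 ug/mL
- compound 2 `COc1ccc(OC)c(C2=C(c3cc(OC)c(OC)c(OC)c3)C(=O)CC2O)c1`: > 100 ug/mL, a limit
- compound 3 `O/N=C1/CC(O)C(c2ccccc2)=C1c1ccccc1`: > 100 ug/mL, a limit

For the measured compounds named here, compound 1, at 9.5 ug/mL, is the only compound with a number. Compound 2 and compound 3 stand at the limit of > 100 ug/mL in this assay, at which 2 of the 3 values shown sit.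

Compound 4 `COc1ccc(C2=C(c3cc(OC)c(OC)c(OC)c3)C(=O)CC2O[SiH2]C(C)(C)C)cc1O` differs from compound 1 by 3-hydroxy-4-methoxyphenyl in place of 2,5-dimethoxyphenyl on a double-bonded ring carbon. Going by the values given here, no measured step varies this group. Among the compounds with values here, the only measured step, an at least 10-fold higher number from compound 1 to compound 2 (1.02 log units; beyond the scatter), is large, but it concerns the group on the oxygen, which compound 4 keeps. No step beyond the scatter is therefore expected in this assay, though with wide uncertainty. The estimated change is a 1.9-fold lower number from compound 1 to compound 4 (0.28 log units; within the scatter). For compound 4 the expected value is 5 ug/mL, with an estimated range of 0.8 ug/mL to 30 ug/mL.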

Compound 4, half-maximal inhibitory concentration: 42 ug/mL
Beside the measured number, compound 4's estimate is 8.4-fold (0.92 log units) below it, outside the stated range (above it).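

In this assay, the aryl group on the double-bonded ring carbon is not a silent position: 3-hydroxy-4-methoxyphenyl in place of 2,5-dimethoxyphenyl gives a 4.4-fold higher number from compound 1 to compound 4 (0.65 log units; beyond the scatter). For the compounds shown here, the group on the oxygen stays the same in this pair, so the earlier step on that oxygen is no longer the only change beyond the scatter. Nothing shown gives a cause for this step.

This single exchange alters both the hydroxy and the methoxy pattern, so the contribution of each remains unresolved. On these data alone, whether 3-amino-4-methoxyphenyl or 3,4-dimethoxyphenyl would behave like 3-hydroxy-4-methoxyphenyl remains open.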